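The source may hold more compounds than are shown below. What is called first, only, known or untested is meant among the compounds shown, and "the series" means these compounds.

Measured in a functional assay on RXF 393 cells (Homo sapiens) for inhibition, read by sulforhodamine B assay, with a stated time of 48 h; a higher number here means a weaker inhibitor of growth, a lower number a stronger inhibitor of growth:
- compound 1 `COc1cc(-c2cc(/C=C/C(=O)c3ccc(Cl)c(Cl)c3)[nH]n2)cc(OC)c1OC` gives 2700 nM
- compound 2 `COc1ccc(C(=O)/C=C/c2cc(-c3cc(OC)c(OC)c(OC)c3)n[nH]2)cc1OC` gives 1350 nM
- compound 3 `COc1cc(-c2cc(/C=C/C(=O)c3ccc(F)c(F)c3)[nH]n2)cc(OC)c1OC` gives 2050 nM

Compound 2 has the lowest of the three numbers, but its separation from the others is small: a 1.5-fold higher number from compound 2 to compound 3 (0.18 log units; within the scatter) and a 2.0-fold lower number from compound 1 to compound 2 (0.30 log units; within the scatter) both stay inside the scatter, as does a 1.3-fold lower number from compound 1 to compound 3 (0.12 log units; within the scatter). All three compounds share the same core and differ only in the aryl group on the carbonyl carbon.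

Compound 4 `COc1cc(C(=O)/C=C/c2cc(-c3cc(OC)c(OC)c(OC)c3)n[nH]2)cc(OC)c1OC` is the next step from compound 2: methoxy in place of hydrogen on an aromatic carbon. Going by the values given here, none of the measured steps adds a methoxy to an aryl group that already carries methoxy groups; the steps that exist all swap one substituted aryl on the carbonyl carbon for another, and each stays within the scatter. On that basis the expected step in this assay is a 1.1-fold higher number from compound 2 to compound 4 (0.05 log units; within the scatter), that is, no change beyond the scatter in either direction. Compound 4 is therefore estimated at 1500 nM, with a range from 600 nM to 4000 nM.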

Compound 4, concentration for 50% growth inhibition: 1260 nM
Compound 4: middle estimate off by 1.2-fold (0.08 log units), on the high side, within the range that was stated.
By their numbers in this assay, from the lowest: compounds 4, 2, 3 and 1 (each within the scatter of the next, the first and the last beyond it).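

In this assay, methoxy in place of hydrogen on an aromatic carbon, ortho to a methoxy group and meta to a large group, gives a 1.1-fold lower number from compound 2 to compound 4 (0.03 log units; within the scatter), so the aryl group on the carbonyl carbon accepts a methoxy at this position with no change beyond the scatter. The earlier steps shown here swapped one substituted aryl for another, whereas this one adds a group to an aryl that already carries methoxy groups, and it also stays within the scatter. Nothing measured here gives a reason for this result.

On these data alone, whether this position accepts other groups remains open: a hydroxyl, an amine, a carboxylic acid or a longer chain such as ethoxy would test that. As far as these compounds go, it is also open whether the same methoxy step would stay within the scatter on the 3,4-dichlorophenyl or 3,4-difluorophenyl group.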